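Removing the chloro from a diaryl urea inhibitor

The source may report more compounds than this note shows. Statements on the series, on what has been measured and on what is new or still open speak of the compounds shown alone.

Two diaryl ureas sharing the same core have been measured in a functional assay on HT-29 cells (Homo sapiens) for antiproliferative activity, read by MTT assay, with a stated time of 72 h; a lower number here means a stronger inhibitor, a higher number a weaker inhibitor. Compound 1 `CN(C)CCn1cnnc1-c1cc(Oc2ccc(NC(=O)Nc3cccc(C(F)(F)F)c3)cc2F)ccn1` gives 1470 nM. Compound 2 `CCN(CC)CCn1cnnc1-c1cc(Oc2ccc(NC(=O)Nc3ccc(Cl)c(C(F)(F)F)c3)cc2F)ccn1` gives 900 nM in this assay . On the numbers shown, compound 2 carries the smaller value, yet the two results lie within the scatter of one another, so neither compound can be called the stronger inhibitor. Compound 3 `CCN(CC)CCn1cnnc1-c1cc(Oc2ccc(NC(=O)Nc3cccc(C(F)(F)F)c3)cc2F)ccn1` has not yet been measured in this assay . It differs from compound 2 by hydrogen in place of chloro on an aromatic carbon. Among the measured compounds shown here, since compound 1 and compound 2 differ in two places at once, no single step between measured compounds separates this change from the change in the amine. The expected step from compound 2 to compound 3 is estimated as a 1.4-fold higher number from compound 2 to compound 3 (0.16 log units; within the scatter), a small shift toward a higher number and not beyond the scatter. Compound 3 is therefore expected to give about 1300 nM in this assay , with a range from 500 nM to 3500 nM.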

Compound 3, half-maximal inhibitory concentration: 630 nM
Estimate against measurement, compound 3: 2.1-fold (0.31 log units) above; the range from low to high includes it.
By their numbers in this assay, from the lowest: compounds 3, 2 and 1 (each within the scatter of the next, the first and the last beyond it).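

In this assay, hydrogen in place of chloro on this aromatic carbon, ortho to the trifluoromethyl group, gives a 1.4-fold lower number from compound 2 to compound 3 (0.15 log units; within the scatter), so the 4-chloro-3-(trifluoromethyl)phenyl and 3-(trifluoromethyl)phenyl groups cannot be told apart here. Among the compounds shown here, compound 3 also isolates the change in the amine for the first time: diethylamino in place of dimethylamino gives a 2.3-fold lower number from compound 1 to compound 3 (0.37 log units; beyond the scatter), a modest step and the only single-place step here beyond the scatter. Nothing available accounts for either step.

From the compounds shown here alone, whether fluoro, methyl or methoxy at the chloro position would stay within the scatter of compound 3 remains open, as does the size of the chloro step with a dimethylamino chain. Only two amines are shown, so the outcome with morpholine, pyrrolidine or a longer chain to the amine is also unknown.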